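The compounds below may be only part of what the source reports. "The series", "measured", "known", "first", "only" and "open" are said of these compounds alone.

Compound 2, `O=C(O)/C(=N/OC(c1ccc(OCc2ccc3ccccc3n2)cc1)C1CCCCC1)c1ccccc1`, gives 31 nM in a functional assay for inhibition of Polyunsaturated fatty acid 5-lipoxygenase (Homo sapiens); a lower number here means a stronger inhibitor, a higher number a weaker inhibitor. Among the three compounds with numbers it holds the second highest value: compound 3, `O=C(O)/C(CCc1ccccc1)=N/OC(c1ccc(OCc2ccc3ccccc3n2)cc1)C1CCCCC1`, at 20 nM lies nearest, and the step from compound 2 to compound 3 (a 1.6-fold lower number from compound 2 to compound 3 (0.19 log units; within the scatter)) stays within the scatter, while compound 1, `O=C(O)/C(CSCCO)=N/OC(c1ccc(OCc2ccc3ccccc3n2)cc1)C1CCCCC1`, at 181 nM lies furthest, the step from compound 1 to compound 2 being a 5.8-fold lower number from compound 1 to compound 2 (0.77 log units; beyond the scatter). Compound 4, `O=C(O)c1ccc(/C=N/OC(c2ccc(OCc3ccc4ccccc4n3)cc2)C2CCCCC2)cc1`, differs from compound 2 by a group of 11 heavy atoms (8 carbon, 1 nitrogen, 2 oxygen; one six-membered aromatic ring of carbon only) in place of a group of 11 heavy atoms (8 carbon, 1 nitrogen, 2 oxygen; one six-membered aromatic ring of carbon only), on an oxygen on a saturated carbon; the two have the same atoms, joined differently. The measured steps all exchange the group on the carbon with a double bond to nitrogen while leaving the rest untouched: a 5.8-fold lower number from compound 1 to compound 2 (0.77 log units; beyond the scatter), a 9.1-fold lower number from compound 1 to compound 3 (0.96 log units; beyond the scatter) and a 1.6-fold lower number from compound 2 to compound 3 (0.19 log units; within the scatter). For the measured compounds named here, none of them rearranges the atoms as this change does, so no measured step bears directly on it, and a modest step is expected, probably towards a higher number. On that basis compound 4 is estimated at 100 nM, within 25 nM to 400 nM, an expected step of a 3.2-fold higher number from compound 2 to compound 4 (0.51 log units; beyond the scatter).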

Compound 4, half-maximal inhibitory concentration: 31 nM
Beside the measured number, compound 4's estimate is 3.2-fold (0.51 log units) above it, and the stated range covers the measured number.
By their numbers in this assay, from the lowest: compounds 3, 2 and 4 (each within the scatter of the next); then compound 1.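

In this assay, for the compounds shown here, the earlier steps all exchanged the group on the carbon with a double bond to nitrogen while the carboxylic acid stayed on that carbon, whereas this change joins the same atoms differently and puts the carboxylic acid on the six-membered aromatic ring. The result is no change at the digits printed from compound 2 to compound 4 (within the scatter), so in this pair the carboxylic acid can leave that carbon without a change beyond the scatter, and the rearranged group also gives a 5.8-fold lower number from compound 1 to compound 4 (0.77 log units; beyond the scatter) as its step against the group with no ring. No evidence is available to explain this result.

The compounds shown leave open whether a longer chain between the aromatic ring and the carboxylic acid would keep the number at this level. They also leave open what an amide or a tetrazole in place of the carboxylic acid would give.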